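Methoxy removal in two bromoaryl series under cytotoxicity testing

A few compounds are considered here, and "the series" means these few. Any claim that something is new, unique, unknown or untested is made for them only; others in the source may bear on it.

Compound 1 `COc1cc(Br)cc(/C=C/C(=O)c2ccc(C)cc2)c1O` gives 155% in an ADME assay on MCF-10A cells (Homo sapiens) for cytotoxicity, read by sulforhodamine B assay, with a stated time of 72 h, tested at 10 uM; on this read-out lower numbers stand for a weaker effect and higher numbers for a stronger effect at the one concentration tested. Compound 2 `Cc1ccc(C(=O)/C=C/c2cc(Br)ccc2O)cc1` gives 32.4% in this assay; the change hydrogen in place of methoxy on an aromatic carbon produced a number 122.6 percentage points lower from compound 1 to compound 2 (beyond the scatter). Compound 3 `COc1cccc(C(=O)CC2C(C#N)=C(N)Oc3c(OC)cc(Br)cc32)c1` gives 32.3% in this assay, a number within the scatter of compound 2 and far below compound 1. How the core of compound 3 differs from that of compound 1 is not broken down here.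

Compound 4 `COc1cccc(C(=O)CC2C(C#N)=C(N)Oc3ccc(Br)cc32)c1` carries the same kind of change, (hydrogen in place of methoxy on an aromatic carbon). The surroundings are not the same: in compound 1 the methoxy sits ortho to a hydroxy group and meta to a large group, whereas in compound 3 it sits ortho to a fused ring and meta to a fused ring, on a ring that is part of a fused system of two rings.

The earlier step started from a high number. Compound 3 starts low, so a fall of similar size is not expected; the step from compound 3 to compound 4 is estimated at a number 7.3 percentage points lower from compound 3 to compound 4 (within the scatter). For compound 4 a value of 25% in this assay is expected, between 5% and 50%.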

Compound 4, a percentage reported as activity, at one concentration (the size of the read-out at that concentration, not a potency): 101%
For compound 4 the middle estimate is 76 percentage points below the measured one; measured number above the stated range.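

In this assay, hydrogen in place of methoxy on an aromatic carbon gives a number 68.7 percentage points higher from compound 3 to compound 4 (beyond the scatter), so on this core the change raises the read-out. The same change therefore does not carry over from the core of compound 1 to the core of compound 3 in either direction or size: the same change on two cores in this assay, a number 122.6 percentage points lower (beyond the scatter) from compound 1 to compound 2 and a number 68.7 percentage points higher (beyond the scatter) from compound 3 to compound 4, 191.3 percentage points apart, beyond the scatter of two such steps. With only one matched pair on each core, these results show that the methoxy step cannot be transferred between these two cores, but they do not show which structural difference sets its direction, or whether either direction would hold for other pairs on the same core.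

The compounds shown leave open how an amine, a fluoro group or a longer chain such as ethoxy on the same aromatic carbon would compare with methoxy and hydrogen on each core. They also leave open whether the opposite steps persist when the bromo group or the substituents elsewhere on each core are replaced.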